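Azetidinyl in place of fluoropyridyl on the shared core

The source may report more compounds than this note shows. Statements on the series, on what has been measured and on what is new or still open speak of the compounds shown alone.

Of the compounds shown here, two carry numbers so far. Compound 1 `COc1ccc(CNC(=O)c2cc(-c3cncc(C)c3)ncc2-c2cncc(F)c2)nc1OC` in an assay on CHO cells for displacement of a labelled ligand from Orexin receptor type 2 (Homo sapiens), read by scintillation counting, with a stated time of 3 h (on this read-out lower numbers stand for stronger inhibition and higher numbers for weaker inhibition), gives 5.2 nM, the lower of the two. Compound 2 `COc1ccc(CNC(=O)c2nc(-c3cncc(C)c3)ncc2-c2ccccc2)nc1OC` in this assay gives 11 nM, a number higher than that of compound 1 by more than the usual scatter, though compound 2 also differs from compound 1 in more than one place, so no single step can be read from the pair.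

Compound 3 `COc1ccc(CNC(=O)c2cc(-c3cncc(C)c3)ncc2N2CCC2)nc1OC` has not been measured. It differs from compound 1 by azetidin-1-yl in place of 5-fluoropyridin-3-yl on an aromatic carbon. For the measured compounds named here, no measured pair of the series shows this kind of change, so the expectation rests on compound 1 alone. Going by the values given here, the aromatic group is the only kind seen at this place so far, and its loss is expected to cost potency: the estimated step from compound 1 to compound 3 is a 4.8-fold higher number from compound 1 to compound 3 (0.68 log units; beyond the scatter), upward and beyond the scatter. For compound 3 the expected value in this assay is 25 nM, within a range of 6 nM to 100 nM.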

Compound 3, inhibition constant: 10 nM
Estimate against measurement, compound 3: 2.5-fold (0.40 log units) above; low and high end bracket the measured number.
By their numbers in this assay, from the lowest: compounds 1, 3 and 2 (each within the scatter of the next, the first and the last beyond it).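

In this assay the change to azetidin-1-yl in place of 5-fluoropyridin-3-yl on an aromatic carbon gives a 1.9-fold higher number from compound 1 to compound 3 (0.28 log units; within the scatter), the first step read at this place. An aromatic ring is therefore not required here to stay within the scatter of compound 1: one four-membered non-aromatic ring serves as well in this assay, on this single pair. Nothing at hand explains why the two groups read alike.

Open, going by these compounds, is whether a larger saturated ring such as pyrrolidin-1-yl or morpholin-4-yl, or an open-chain amine such as dimethylamino, would read like azetidin-1-yl at this place. Also open, on these data alone, is how a plain phenyl group would read on the core of compound 1, since a single step cannot separate the role of the ring from that of its fluorine.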